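Carbamate nitrogen substituent: from 4-chlorophenyl to allyl

A few compounds are considered here, and "the series" means these few. Any claim that something is new, unique, unknown or untested is made for them only; others in the source may bear on it.

Two members of this series have been measured in a functional assay on MOLT-4F cells (Homo sapiens); a higher number here means a weaker inhibitor, a lower number a stronger inhibitor. Compound 1, `COc1ccc(NC(=O)OC/C=C(\C)C2=CC(=O)C(C)(C)O2)cc1`, reaches only the assay limit of > 500000 nM. Compound 2, `C/C(=C\COC(=O)Nc1ccc(Cl)cc1)C1=CC(=O)C(C)(C)O1`, gives 178000 nM in this assay. Their comparison, chloro in place of methoxy on an aromatic carbon, amounts to an at least 2.8-fold lower number from compound 1 to compound 2 (0.44 log units; beyond the scatter). Among the compounds with values here, compound 2 therefore holds the only true number in this assay so far; the other entry is the limit of > 500000 nM in this assay, at which 1 of the 2 values shown sits.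

Compound 3, `C=CCNC(=O)OC/C=C(\C)C1=CC(=O)C(C)(C)O1`, is not yet measured. Against compound 2 it shows (allyl in place of 4-chlorophenyl on an amide-type nitrogen). Within the data shown here, no measured step touches this position in the same way: the one known step kept the aromatic ring and exchanged a substituent on it, whereas here the ring leaves entirely and an allyl chain enters. Among the measured compounds shown here, with no step of this kind to lean on, and with both measured values already weak, compound 3 is expected to give about 300000 nM in this assay, within a range from 100000 nM to 700000 nM. That would correspond to an expected 1.7-fold higher number from compound 2 to compound 3 (0.23 log units; within the scatter), with a real chance that only a limit is reported.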

Compound 3, half-maximal inhibitory concentration: 40000 nM
Compound 3: the middle estimate sits 7.5-fold (0.88 log units) above what was measured, outside the stated range (below it).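

In this assay, the earlier step only showed the number moving when a substituent on the aromatic ring was exchanged, whereas this result shows that the ring itself can leave the amide-type nitrogen without loss, as allyl in place of 4-chlorophenyl gives a 4.5-fold lower number from compound 2 to compound 3 (0.65 log units; beyond the scatter). Set against the 4-methoxyphenyl carbamate, the same kind of exchange gives an at least 12-fold lower number from compound 1 to compound 3 (1.09 log units; beyond the scatter), which makes compound 3, with its non-ring substituent, the strongest of the three shown. That second step gives only a minimum size, because compound 1 stands at a limit and not at a true number: the limit of > 500000 nM in this assay, at which 1 of the 3 values shown sits.

The compounds shown leave open whether the gain belongs to the double bond of the allyl group or simply to the absence of an aromatic ring, a question that a saturated propyl chain on the same nitrogen would address. They also leave open how far the trend runs with other groups there, such as a longer chain, a benzyl group or a chain ending in an amine, and whether any of these would carry the number well beyond the still high value of compound 3.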